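The source may report more compounds than this note shows. Statements on the series, on what has been measured and on what is new or still open speak of the compounds shown alone.

Compound 1 `Cc1c(OCCCCOc2ccc(C(=O)O)cc2Cl)ccc(C(=O)CC2CCCC2)c1O` gives 27.4% in an assay on HEK293 cells for positive allosteric modulation of metabotropic glutamate receptor 3 (Rattus norvegicus), read by thallium flux, with a stated time of 2.5 min; a lower number here means a smaller maximal response, a higher number a larger maximal response; compound 2 `Cc1c(OCCCCOc2ccc(C(=O)O)cc2Cl)ccc(C(=O)CC(C)C)c1O` gives 62.9%; compound 3 `Cc1cc(OCCCCOc2ccc(C(=O)CC(C)C)c(O)c2C)ccc1C(=O)O` gives 41.9%.

Compound 1 thus holds the lowest of the three numbers, with compound 3 nearest and compound 2 furthest, the latter gap being a number 35.5 percentage points higher from compound 1 to compound 2 (beyond the scatter). Compound 4 `Cc1cc(C(=O)O)ccc1OCCCCOc1ccc(C(=O)CC2CCCC2)c(O)c1C` differs from compound 1 in one place: methyl in place of chloro on an aromatic carbon. Among the compounds with values here, only one measured step touches this aryl group, a number 21 percentage points lower from compound 2 to compound 3 (beyond the scatter), a modest fall; but there the ring that enters is 4-carboxy-3-methylphenyl, not 4-carboxy-2-methylphenyl, so it guides compound 4 only loosely. With compound 1 already at the low end, no step beyond the scatter is expected, at most a slight fall, a number 3.4 percentage points lower from compound 1 to compound 4 (within the scatter). Compound 4 is therefore expected to give 24%, in the range 12% to 38%.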

Compound 4, largest response reached (reported as percent of maximum), in percent of the reference or control that the assay uses: 28.4%
Beside the measured number, compound 4's estimate is 4.4 percentage points below it; low and high end bracket the measured number.
By their numbers in this assay, from the lowest: compounds 1 and 4 (each within the scatter of the next); then compound 3; then compound 2.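

With the cyclopentyl side chain in place, methyl serves on this aromatic carbon as well as chloro does, a number 1 percentage points higher from compound 1 to compound 4 (within the scatter) in this assay, so the exchange of these two groups alone leaves the maximal response unmoved. The fall a number 21 percentage points lower from compound 2 to compound 3 (beyond the scatter) therefore cannot simply be read as the loss of chloro, although that step has the isopropyl side chain and a methyl placed differently on the ring. Nothing at hand explains why chloro and methyl read alike here.

As far as these compounds go, whether 4-carboxy-2-methylphenyl behaves the same way alongside the isopropyl side chain remains open. So does the effect of a fluoro, methoxy or nitrile group on this carbon.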